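The source may report more compounds than this note shows. Statements on the series, on what has been measured and on what is new or still open speak of the compounds shown alone.

Measured compounds:
Compound 1, `COc1ccc2nc(C)c3c(c2c1)CC[C@]1(C[C@H]2C(=O)N[C@]4(C(=O)NS(=O)(=O)C5(C)CC5)C[C@H]4/C=C\CCCCC[C@H](NC(=O)OC(C)(C)C)C(=O)N2C1)O3`: 62.4 ng.h/mL
Compound 2, `COc1ccc2nc(C)c3c(c2c1)CC[C@]1(C[C@H]2C(=O)N[C@]4(C(=O)NS(=O)(=O)C5(C)CC5)C[C@H]4/C=C\CCCCC[C@H](NC(=O)OCC(C)C)C(=O)N2C1)O3`: 101 ng.h/mL

Both compounds were run in an ADME assay on the whole organism for pharmacokinetics, with Rattus norvegicus as the target, with a stated time of 24 h, at a dose of 5 mg/kg by the oral route; on this read-out lower numbers stand for lower exposure and higher numbers for higher exposure at the dose given. Compound 1 gives 62.4 ng.h/mL in this assay, and compound 2 gives 101 ng.h/mL. For the measured compounds named here, the one measured step, a 1.6-fold higher number from compound 1 to compound 2 (0.21 log units; within the scatter), changes the group on an oxygen next to a carbonyl group, and its size lies within the scatter. Compound 2 therefore holds the highest of the two numbers, though its gap to compound 1 is not one that can be called a difference.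

Compound 3, `COc1ccc2nc(C3CC3)c3c(c2c1)CC[C@]1(C[C@H]2C(=O)N[C@]4(C(=O)NS(=O)(=O)C5(C)CC5)C[C@H]4/C=C\CCCCC[C@H](NC(=O)OCC(C)C)C(=O)N2C1)O3`, is the next compound and has not yet been measured in this assay. It differs from compound 2 in one place: cyclopropyl in place of methyl on an aromatic carbon. Going by the values given here, no measured step touches this aromatic carbon, so the only guidance is the step from compound 1 to compound 2, which shows that one change elsewhere on this scaffold moved the number by no more than the scatter. On that basis compound 3 is expected to show a step of about a 1.0-fold lower number from compound 2 to compound 3 (0.00 log units; within the scatter), no change beyond the scatter in either direction. The estimate for compound 3 is therefore 100 ng.h/mL, with a range from 35 ng.h/mL to 300 ng.h/mL.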

Compound 3, area under the concentration-time curve: 1850 ng.h/mL
Estimate against measurement, compound 3: 19-fold (1.27 log units) below; measured number above the stated range.
By their numbers in this assay, from the lowest: compounds 1 and 2 (each within the scatter of the next); then compound 3.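

In this assay, putting cyclopropyl in place of methyl on an aromatic carbon next to the ring nitrogen gives an 18-fold higher number from compound 2 to compound 3 (1.26 log units; beyond the scatter), a large step. For the compounds shown here, the earlier step, a 1.6-fold higher number from compound 1 to compound 2 (0.21 log units; within the scatter), changed the group on an oxygen next to a carbonyl group and stayed within the scatter, so this aromatic carbon is the first place on the shared core where a single change is seen to alter exposure at the dose given by a clear margin. The compounds shown offer no measurement that would account for the size of this step.

Only methyl and cyclopropyl are shown on this aromatic carbon, so it remains open whether the rise belongs to cyclopropyl in particular or would also appear with ethyl, isopropyl, cyclobutyl, methoxy or an amine there. On these data alone, it is also open whether the same change would give a step of similar size with tert-butyl rather than isobutyl on the oxygen next to the carbonyl group, since cyclopropyl appears here only alongside isobutyl.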